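Working notes: from compound 2 to compound 3

This account rests on a few compounds, and the source may have more. Where it says the series, first, only, none or still open, it means among the compounds named here.

Measured in a functional assay on SiHa cells (Homo sapiens) for inhibition, read by sulforhodamine B assay; on this read-out higher numbers stand for weaker inhibition of growth and lower numbers for stronger inhibition of growth:
- compound 1 `Oc1cccc2[nH]c(-c3ccc(-c4ccc(-c5ccccc5)cc4)cc3)nc12`: 9710 nM
- compound 2 `Oc1cccc2[nH]c(-c3ccc(-c4ccc(-c5ccc(OC(F)(F)F)cc5)cc4)cc3)nc12`: 8410 nM

Among the measured compounds shown here, compound 2 gives 8410 nM, level with its only measured neighbour. For the measured compounds named here, the single step available, a 1.2-fold lower number from compound 1 to compound 2 (0.06 log units; within the scatter), does not separate the two compounds.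

The next compound is compound 3 `COc1ccc(-c2ccc(-c3ccc(-c4nc5c(O)cccc5[nH]4)cc3)cc2)cc1OC`. The change is 3,4-dimethoxyphenyl in place of 4-(trifluoromethoxy)phenyl on an aromatic carbon. Going by the values given here, the only guide is that same measured step, a 1.2-fold lower number from compound 1 to compound 2 (0.06 log units; within the scatter), which concerned the trifluoromethoxy group that now leaves. Among the compounds with values here, no measured compound carries 3,4-dimethoxyphenyl, so this guide is thin. In this assay, no shift beyond the scatter is expected in either direction. The expected step is a 1.0-fold higher number from compound 2 to compound 3 (0.00 log units; within the scatter). The estimate for compound 3 is 8500 nM, with an expected range of 4000 nM to 18000 nM.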

Compound 3, concentration for 50% growth inhibition: 1110 nM
Compound 3: the middle estimate sits 7.7-fold (0.88 log units) above what was measured; measured number outside the range, below it.
By their numbers in this assay, from the lowest: compound 3; then compounds 2 and 1 (each within the scatter of the next).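

In this assay this position does respond to substitution: 3,4-dimethoxyphenyl in place of 4-(trifluoromethoxy)phenyl gives a 7.6-fold lower number from compound 2 to compound 3 (0.88 log units; beyond the scatter), whereas the earlier step to trifluoromethoxy stayed within the scatter. Set against the unsubstituted phenyl, the change reads the same way, with an 8.7-fold lower number from compound 1 to compound 3 (0.94 log units; beyond the scatter), so compound 3 stands apart from two compounds that remain level with each other. Nothing available accounts for the shift.

The compounds shown leave open whether a single methoxy group would carry the shift or both are required, and whether a hydroxyl or an amine on the same ring would do as well. Equally open, as far as these compounds go, is whether an ethoxy group or a longer alkoxy chain in place of methoxy would hold the number where compound 3 puts it.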